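Swapping the piperazine carbamate arm for a short amide chain

This account rests on a few compounds, and the source may have more. Where it says the series, first, only, none or still open, it means among the compounds named here.

Of the compounds shown here, three of one series have been measured in a functional assay for agonist activity at 5-hydroxytryptamine receptor 4 (Homo sapiens), read by cAMP accumulation; on this read-out lower numbers stand for smaller maximal responses and higher numbers for larger maximal responses. Compound 1 `CCc1nc2c(C(=O)NCC3CCN(CC(O)CN4CCN(S(C)(=O)=O)CC4)CC3)cccc2[nH]1` gives 22%. Compound 2 `CS(=O)(=O)N1CCN(CC(O)CN2CCC(NC(=O)c3cccc4[nH]cnc34)CC2)CC1` gives 7%. Compound 3 `COC(=O)N1CCN(CCN2CCC(CNC(=O)c3cccc4[nH]c(C(C)C)nc34)CC2)CC1` gives 72%, the highest of the three numbers: its gap to compound 1 and its larger gap to compound 2 both lie beyond the usual scatter of this assay, so compound 3 stands out as the strongest of the measured set.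

Compound 4 `CC(=O)N(C)CC(O)CN1CCC(CNC(=O)c2cccc3[nH]c(C(C)C)nc23)CC1` has not yet been measured. It differs from compound 3 in one place: 2-(acetyl(methyl)amino)-1-hydroxyethyl in place of (4-(methoxycarbonyl)piperazin-1-yl)methyl on a saturated chain carbon bound to an amine nitrogen in a ring. The ring-bearing arm is gone, and a shorter, ring-free chain with one hydrogen-bond donor takes its place. Going by the values given here, no measured pair shows this exact change, so the size of the step is uncertain. The chain bearing a hydroxyl does recur in compound 1, which gives 22%, and in compound 2, which gives 7%, both well below compound 3, but those two also carry a different distal group, so they do not isolate this change.

On balance a decrease is expected from compound 3 to compound 4, of a number 27 percentage points lower from compound 3 to compound 4 (beyond the scatter). Compound 4 is estimated to give 45% in this assay, within a range from 15% to 80%.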

Compound 4, intrinsic activity: the largest response reached, in percent of the reference agonist's: 64%
Compound 4: middle estimate off by 19 percentage points, on the low side; the range from low to high includes it.
By their numbers in this assay, from the lowest: compound 2; then compound 1; then compounds 4 and 3 (each within the scatter of the next).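

In this assay, putting 2-(acetyl(methyl)amino)-1-hydroxyethyl in place of (4-(methoxycarbonyl)piperazin-1-yl)methyl gives a number 8 percentage points lower from compound 3 to compound 4 (within the scatter), so this pair cannot be told apart on maximal response. For this pair, then, the six-membered ring of the leaving arm is not required at this place, on a saturated chain carbon bound to an amine nitrogen in a ring, and a ring-free arm bearing a hydroxyl can take its place with a response of the same order. The data at hand offer no explanation for this match.

The hydroxyl and the acetyl(methyl)amino part enter in a single step, so the compounds shown leave open what each contributes alone. As far as these compounds go, how a carboxylic acid or a longer chain would behave at this place also remains open.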